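Cyano for Chloro on the Benzamide of Compound 3

The source may hold more compounds than are shown below. What is called first, only, known or untested is meant among the compounds shown, and "the series" means these compounds.

Measured compounds in an ADME assay on RAW264.7 cells (Mus musculus) for cytotoxicity, read by MTT assay, with a stated time of 48 h; on this read-out lower numbers stand for stronger inhibition and higher numbers for weaker inhibition:
compound 1 `CCS(=O)(=O)Nc1ccc(NC(=O)c2ccc(C#N)cc2)cc1C` gives 109000 nM
compound 2 `CS(=O)(=O)Nc1ccc(NC(=O)c2ccc(C#N)cc2)cc1F` gives > 250000 nM
compound 3 `CCS(=O)(=O)Nc1ccc(NC(=O)c2ccc(Cl)cc2)cc1F` gives 152000 nM

The value of compound 2 in this assay is a limit, not a number (the limit of > 250000 nM in this assay, at which 1 of the 3 values shown sits). Among the two compounds that give a number, compound 3 and compound 1 sit within the usual scatter of each other, so no order between them can be read from this assay.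

Compound 4 `CCS(=O)(=O)Nc1ccc(NC(=O)c2ccc(C#N)cc2)cc1F` has not yet been measured. It differs from compound 3 in one place: cyano in place of chloro on an aromatic carbon. Among the compounds with values here, no pair of measured compounds differing only in this way is available, so the size of the step cannot be taken from a measured pair. What the other compounds show is that a cyano group on this ring is compatible with a number in this assay, as compound 1 gives 109000 nM. Compound 2 also carries the cyano group, and its value in this assay is a limit.

From compound 3 to compound 4 a step of a 1.1-fold higher number from compound 3 to compound 4 (0.05 log units; within the scatter) is expected, which lies within the scatter. Compound 4 is estimated at 170000 nM, with a range from 80000 nM to 300000 nM.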

Compound 4, half-maximal inhibitory concentration: 107000 nM
The estimate for compound 4 lay 1.6-fold (0.20 log units) above the measured number; measured number inside the range.
By their numbers in this assay, from the lowest: compounds 4, 1 and 3 (each within the scatter of the next). At a limit, above all of these: compound 2.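

In this assay, the first pair differing only by the 4-chlorophenyl to 4-cyanophenyl exchange gives a 1.4-fold lower number from compound 3 to compound 4 (0.15 log units; within the scatter), and fluoro in place of methyl on an aromatic carbon gives a 1.0-fold lower number from compound 1 to compound 4 (0.01 log units; within the scatter), so neither change can be told apart from repeat measurement here. Within the data shown here, the one step beyond the scatter lies elsewhere in the molecule, at the saturated chain carbon bound to the sulfonyl sulfur, where methyl in place of hydrogen gives an at least 2.3-fold lower number from compound 2 to compound 4 (0.36 log units; beyond the scatter). The size of that step remains open-ended, as the value of compound 2 is a limit and not a number: the limit of > 250000 nM in this assay, at which 1 of the 4 values shown sits.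

The compounds shown leave open whether an amine or a carboxylic acid at the place of the chloro and cyano groups would give a step beyond the scatter in this assay. They also leave open whether a longer chain on the sulfonyl sulfur would extend the step seen with methyl in place of hydrogen.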